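Swapping Difluoromethyl for Ethyl on a Shared Core

The source may report more compounds than this note shows. Statements on the series, on what has been measured and on what is new or still open speak of the compounds shown alone.

Of the compounds shown here, three built on a shared core have been tested in an assay for binding affinity to Corticotropin releasing factor receptor (Rattus norvegicus); a lower number here means a stronger inhibitor, a higher number a weaker inhibitor. Compound 1 `CCCC(C)n1c(CC)nc2c(-c3ccc(/C(C)=N\OC)cc3Cl)ccnc21` gives 2.3 nM. Compound 2 `CCc1nc2c(-c3ccc(Cl)cc3Cl)ccnc2n1C(C)C1CCC1` gives 1 nM. Compound 3 `CCCC(C)n1c(C(F)F)nc2c(-c3ccc(Cl)cc3Cl)ccnc21` gives 15.8 nM, the highest of the three numbers, lying beyond the usual scatter from both others, so it is the weakest binder of the set. Compound 4 `CCCC(C)n1c(CC)nc2c(-c3ccc(Cl)cc3Cl)ccnc21` has not yet been measured; it differs from compound 3 by ethyl in place of difluoromethyl on an aromatic carbon. Going by the values given here, no measured pair shows exactly this change, so its size must be inferred. Compound 1 and compound 2 both carry an ethyl group on the core and bind strongly, so a clear drop in the number is expected. Compound 4 is expected to take the step of a 6.3-fold lower number from compound 3 to compound 4 (0.80 log units; beyond the scatter). The estimate for compound 4 is 2.5 nM, within a range from 1 nM to 7 nM.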

Compound 4, inhibition constant: 0.5 nM
For compound 4 the middle estimate is 5.0-fold (0.70 log units) above the measured one, outside the stated range (below it).
By their numbers in this assay, from the lowest: compounds 4 and 2 (each within the scatter of the next); then compound 1; then compound 3.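

In this assay, going by these compounds alone, ethyl in place of difluoromethyl on this aromatic carbon gives a 32-fold lower number from compound 3 to compound 4 (1.50 log units; beyond the scatter), the first direct reading of this change and the largest step in the set. With ethyl kept in this place, propyl in place of cyclobutyl gives a 2.0-fold lower number from compound 2 to compound 4 (0.30 log units; within the scatter), while one chlorine atom in place of the larger group of 5 heavy atoms gives a 4.6-fold lower number from compound 1 to compound 4 (0.66 log units; beyond the scatter). Nothing in the data explains the size of the ethyl step. Going by these compounds, how an amine or a longer chain on this aromatic carbon would compare remains open. On these data alone, whether the step keeps its size with other groups elsewhere on the shared core is also open.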